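The source may report more compounds than this note shows. Statements on the series, on what has been measured and on what is new or still open speak of the compounds shown alone.

Among the compounds with values here, in a functional assay on K562 cells (Homo sapiens) for antiproliferative activity, read by CCK-8 assay, with a stated time of 72 h (a lower number here means a stronger inhibitor of growth, a higher number a weaker inhibitor of growth), compound 1 (`CCC1C(=O)N(C)c2cnc(-n3ccc4cc(C(=O)NC(C)C)ccc43)nc2N1c1ccn(C)n1`) gives 8910 nM, the highest of the three numbers measured so far. Compound 2 (`CC[C@@H]1C(=O)N(C)c2cnc(Nc3ccc(S(=O)(=O)Nc4ccccc4)cc3)nc2N1C1CCCC1`) gives 4180 nM and compound 3 (`CCCNC(=O)c1ccc2c(ccn2-c2ncc3c(n2)N(C2CCCC2)[C@H](CC)C(=O)N3C)c1`) gives 395 nM, both lower than compound 1 by more than the usual scatter. Compound 4 (`CCCCNC(=O)c1ccc2c(ccn2-c2ncc3c(n2)N(c2ccn(C)n2)C(CC)C(=O)N3C)c1`) keeps the core of compound 1 and changes one group: butyl in place of isopropyl on an amide-type nitrogen, with butyl in place of isopropyl on an amide-type nitrogen. Within the data shown here, no measured pair isolates this swap, so the data offer no direct guide to its size. A moderate move towards stronger growth inhibition in this assay is expected, an estimated 2.2-fold lower number from compound 1 to compound 4 (0.35 log units; beyond the scatter). For compound 4 the estimated value is 4000 nM, with an expected range from 1200 nM to 12000 nM.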

Compound 4, concentration for 50% growth inhibition: 14100 nM
Beside the measured number, compound 4's estimate is 3.5-fold (0.55 log units) below it; the whole stated range lies below it.
By their numbers in this assay, from the lowest: compound 3; then compound 2; then compounds 1 and 4 (each within the scatter of the next).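

Within the data shown here, putting butyl in place of isopropyl on the amide-type nitrogen gives a 1.6-fold higher number from compound 1 to compound 4 (0.20 log units; within the scatter) in this assay, the first direct reading at this position. On the core of compound 1, these two small carbon chains cannot be told apart in this assay, so the extra carbon and the unbranched shape bring no measurable gain in growth inhibition. No measurement at hand bears on why. Still open, on these data alone, is whether a much longer chain, a ring, or a chain ending in an amine or a carboxylic acid would behave differently here.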